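Swapping one ring substituent on a low-toxicity compound

The source may hold more compounds than are shown below. What is called first, only, known or untested is meant among the compounds shown, and "the series" means these compounds.

Measured in a toxicity assay on HepG2 2.2.15 cells (Homo sapiens) for cytotoxicity, read by CellTiter-Glo; on this read-out higher numbers stand for lower toxicity in this test and lower numbers for higher toxicity in this test:
Compound 1 `O=C(Nc1cc(F)c(F)c(F)c1)N1Cc2c(-c3ccc(F)cc3F)cnn2CC1C1CC1`: 32100 nM
Compound 2 `O=C1OC(c2ccccc2)CN1c1cnn2c1CN(C(=O)Nc1cc(F)c(F)c(F)c1)C(C1CC1)C2`: 7410 nM
Compound 3 `O=C1CC(Oc2ncc(F)cn2)CN1c1cnn2c1CN(C(=O)Nc1cc(F)c(F)c(F)c1)C(C1CC1)C2`: 96200 nM

Compound 3 has the highest of these numbers, which means the lowest toxicity in this assay. Compound 1 lies closest to it, and compound 2 lies furthest away. Compound 4 `O=C1CC(c2cnco2)CN1c1cnn2c1CN(C(=O)Nc1cc(F)c(F)c(F)c1)C(C1CC1)C2` differs from compound 3 in one group: 1,3-oxazol-5-yl in place of (5-fluoropyrimidin-2-yl)oxy on a saturated ring carbon. Here, 1,3-oxazol-5-yl takes the place of (5-fluoropyrimidin-2-yl)oxy on a saturated ring carbon.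

Within the data shown here, no measured step changes that carbon. Among the measured compounds shown here, the only step available, a 4.3-fold lower number from compound 1 to compound 2 (0.64 log units; beyond the scatter), swaps a different group on an aromatic carbon, so it offers only a rough guide to size. It suggests a modest move, and the top position of compound 3 at 96200 nM makes a downward direction the likelier one. The expected change is a 2.4-fold lower number from compound 3 to compound 4 (0.38 log units; beyond the scatter). For compound 4 the estimated value is 40000 nM, with an expected range from 13000 nM to 100000 nM.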

Compound 4, half-maximal cytotoxic concentration: 139000 nM
For compound 4 the middle estimate is 3.5-fold (0.54 log units) below the measured one, and the stated range ends below it.
By their numbers in this assay, from the lowest: compound 2; then compound 1; then compounds 3 and 4 (each within the scatter of the next).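

In this assay the swap of (5-fluoropyrimidin-2-yl)oxy for 1,3-oxazol-5-yl, on a saturated ring carbon two ring bonds from the ring nitrogen, gives a 1.4-fold higher number from compound 3 to compound 4 (0.16 log units; within the scatter) and so the two groups cannot be told apart here, even though a six-membered aromatic ring gives way to a five-membered one. The other two comparisons give a 19-fold higher number from compound 2 to compound 4 (1.27 log units; beyond the scatter) and a 4.3-fold higher number from compound 1 to compound 4 (0.64 log units; beyond the scatter) and each replaces a whole group on an aromatic carbon, so the high number of compound 3 is not tied to its pyrimidine ring and also appears with an oxazole on the same carbon. Nothing available here explains these numbers.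

The compounds shown carry only aromatic rings on this carbon. From the compounds shown here alone, whether an amine, a carboxylic acid or a longer alkyl chain there would give a similar number remains open.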